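The source may hold more compounds than are shown below. What is called first, only, known or untested is meant among the compounds shown, and "the series" means these compounds.

Compound 1 `CCCC(=O)Nc1cccc(Oc2cccc(OC)c2)c1`: in an assay on isolated protein for binding affinity to melatonin receptor type 1A (Homo sapiens) (a higher number here means a weaker inhibitor, a lower number a stronger inhibitor), compound 1 gives > 500 nM, which is a limit of the assay rather than a number.
Compound 2 `CCCC(=O)Nc1ccc(Oc2ccc(OC)cc2)cc1`: in this assay compound 2 gives > 500 nM, again a limit of the assay.
Compound 3 `CCC(=O)Nc1ccc(Oc2cccc(OC)c2)cc1`: in this assay compound 3 gives 300 nM.

Compound 3 is therefore the only one of the three with a measured number in this assay; the other two values are limits, as shown by the limit of > 500 nM in this assay, at which 2 of the 3 values shown sit. For the measured compounds named here, no step between measured compounds can be followed here, so the only anchor is compound 3 itself.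

Compound 4 `COCC(=O)Nc1ccc(Oc2cccc(OC)c2)cc1` differs from compound 3 by methoxy in place of methyl on a saturated chain carbon bound to a carbonyl carbon. Going by the values given here, nothing among the measured compounds tells how this change acts in this assay. The expectation is a modest step from compound 3 to compound 4 toward a weaker binder, of a size a 2.0-fold higher number from compound 3 to compound 4 (0.30 log units; within the scatter) that sits only a little beyond the scatter, with a real chance that the assay reports just a limit. For compound 4 the estimate in this assay is 600 nM, with a range from 150 nM to 2500 nM.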

Compound 4, inhibition constant: 180 nM
Estimate against measurement, compound 4: 3.3-fold (0.52 log units) above, within the range that was stated.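

In this assay, methoxy in place of methyl on a saturated chain carbon bound to a carbonyl carbon gives a 1.7-fold lower number from compound 3 to compound 4 (0.22 log units; within the scatter), so the two compounds cannot be told apart. For the compounds shown here, this is the first step that can be followed at this position, and it shows that the added oxygen and the extra heavy atom leave the compound with a measured number rather than a limit. That single step is all there is to go on, and the other values are limits, not numbers: the limit of > 500 nM in this assay, at which 2 of the 4 values shown sit.

As far as these compounds go, whether an amine, a carboxylic acid or a longer chain on this same carbon would also give a number in this assay remains open. The compounds shown also leave open whether the step would look the same on any other core.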